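Compound 4: a step taken from a limit

The source may hold more compounds than are shown below. What is called first, only, known or untested is meant among the compounds shown, and "the series" means these compounds.

Measured in a functional assay on SEM cells (Homo sapiens) for cytotoxicity, with a stated time of 72 h; a higher number here means that more compound is needed for the effect, a lower number that less compound is needed:
Compound 1 `C=C[C@@](C)(/C=C/c1ccc(O)c(CO)c1)CCC=C(C)C`: > 36600 nM (a limit)
Compound 2 `C=C[C@@](C)(/C=C/c1ccc(O)c(/C=C/C(N)=O)c1)CCC=C(C)C`: > 36600 nM (a limit)
Compound 3 `C=C[C@@](C)(/C=C/c1ccc(O)c(/C=C(\C)C(=O)OCC)c1)CCC=C(C)C`: > 36600 nM (a limit)

Compound 3 has no number in this assay, and its > 36600 nM is a limit. Among the compounds with values here, the series so far offers only (the limit of > 36600 nM in this assay, at which 3 of the 3 values shown sit). Compound 4 `C=C[C@@](C)(/C=C/c1ccc(O)c(/C=C/c2ccc(F)cc2)c1)CCC=C(C)C` is still to be measured, and it differs from compound 3 as follows: 2-(4-fluorophenyl)ethenyl in place of 2-(ethoxycarbonyl)prop-1-en-1-yl on an aromatic carbon.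

The measured steps offer little guidance. They are a step that the two limits leave unreadable from compound 1 to compound 2, a step that the two limits leave unreadable from compound 1 to compound 3 and a step that the two limits leave unreadable from compound 2 to compound 3. None of them has a readable size, and none involves the 2-(4-fluorophenyl)ethenyl group, so they give no firm direction. Compound 4 is therefore expected most probably to stay at the same limit, with only a modest chance of a measurable value.

The expected change is an at least 1.2-fold lower number from compound 3 to compound 4 (0.08 log units; that floor lies within the scatter), an estimate that carries little weight. The estimate for compound 4 is 30000 nM, with an expected range from 12000 nM to 60000 nM.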

Compound 4, half-maximal effective concentration: > 36600 nM
Compound 4: only a limit was reported; the forecaster's own chance of this, stated with the estimate: 65%; middle value at least 1.2-fold (0.08 log units) away from the limit.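

In this assay compound 4 gives > 36600 nM, which is a limit. Its steps from compound 1, compound 2 and compound 3 therefore cannot be read. The compounds shown leave open whether any of these groups on the shared core gives a measurable value: the limit of > 36600 nM in this assay, at which 4 of the 4 values shown sit.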